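Notes on the benzyl ether position: from compound 3 to compound 4

The source may hold more compounds than are shown below. What is called first, only, known or untested is meant among the compounds shown, and "the series" means these compounds.

Compound 1, `C#CCOc1ccc2c(=O)c(-c3cc(OC)c(OC)cc3OC)coc2c1`: in a functional assay on A-375 cells (Homo sapiens) for antiproliferative activity, read by MTT assay, with a stated time of 24 h (a higher number here means a weaker inhibitor, a lower number a stronger inhibitor), compound 1 gives 3680 nM.
Compound 2, `COc1ccc2c(=O)c(-c3cc(OC)c(OC)cc3OC)coc2c1`: in this assay compound 2 gives 2640 nM.
Compound 3, `COc1cc(OC)c(-c2coc3cc(OCc4ccccc4F)ccc3c2=O)cc1OC`: in this assay compound 3 gives 2100 nM.

The three measured compounds share one core and differ only at the saturated chain carbon bound to an oxygen on an aromatic ring. The steps between them are a 1.4-fold lower number from compound 1 to compound 2 (0.14 log units; within the scatter), a 1.8-fold lower number from compound 1 to compound 3 (0.24 log units; within the scatter) and a 1.3-fold lower number from compound 2 to compound 3 (0.10 log units; within the scatter), each within the scatter, so the three numbers form a single narrow band in which no substituent at that position has yet separated itself from the others. Compound 3 stands at one edge of that band, but its distances to compound 2 and to compound 1 are both within the scatter, so no ordering among the three can be claimed.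

Compound 4, `COc1cc(OC)c(-c2coc3cc(OCc4ccc([N+](=O)[O-])cc4)ccc3c2=O)cc1OC`, carries 4-nitrophenyl in place of 2-fluorophenyl on a saturated chain carbon bound to an oxygen on an aromatic ring. For the measured compounds named here, no measured step involves a nitro group, so the only steps that bear on this change are those at the same position, a 1.3-fold lower number from compound 2 to compound 3 (0.10 log units; within the scatter) and a 1.8-fold lower number from compound 1 to compound 3 (0.24 log units; within the scatter), both within the scatter. On that basis the step of a 1.2-fold higher number from compound 3 to compound 4 (0.09 log units; within the scatter) is expected to stay within the scatter, with no direction favoured. Compound 4 is therefore estimated to give 2600 nM in this assay, within a range from 1100 nM to 6000 nM.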

Compound 4, half-maximal inhibitory concentration: > 10000 nM
Compound 4 ended at the assay's limit (the forecaster's own chance of this, stated with the estimate: 5%); at least 3.8-fold (0.58 log units) between middle value and limit.
By their numbers in this assay, from the lowest: compounds 3, 2 and 1 (each within the scatter of the next). At a limit, above all of these: compound 4.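

In this assay compound 4 gives > 10000 nM, which is a limit of the assay and not a number. The position on a saturated chain carbon bound to an oxygen on an aromatic ring is therefore not indifferent to what it carries: hydrogen, ethynyl and 2-fluorophenyl there gave numbers within the scatter of one another, whereas 4-nitrophenyl leaves that band, with an at least 4.7-fold higher number from compound 3 to compound 4 (0.67 log units; beyond the scatter), an at least 3.7-fold higher number from compound 2 to compound 4 (0.57 log units; beyond the scatter) and an at least 2.7-fold higher number from compound 1 to compound 4 (0.43 log units; beyond the scatter), all beyond the scatter. Each of these steps has the limit at one end, so it fixes a lower bound on the size of the change and not the size itself: the limit of > 10000 nM in this assay, at which 1 of the 4 values shown sits.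

The change from 2-fluorobenzyl to 4-nitrobenzyl alters both the group on the aromatic ring and where it sits, so compound 4 alone does not show which of the two goes with the loss; a 4-fluorobenzyl or 2-nitrobenzyl ether would separate them. Going by these compounds, it also remains open whether the step belongs to the nitro group as such or extends to other groups in its place, such as a 4-aminobenzyl or 4-carboxybenzyl ether, or an unsubstituted benzyl ether.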